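The source may report more compounds than this note shows. Statements on the series, on what has been measured and on what is new or still open speak of the compounds shown alone.

Notes on the series. Three compounds have been run in an ADME assay on microsomes from liver (Rattus norvegicus) for metabolic stability; on this read-out higher numbers stand for a longer-lived compound and lower numbers for a shorter-lived compound: compound 1 `N#Cc1ccc(NCCNc2ncc(-c3ncc[nH]3)c(-c3ccc(Cl)cc3Cl)n2)nc1`, compound 2 `Nc1nc(NCCNc2ncc(-c3ncc[nH]3)c(-c3cc(F)c(F)cc3F)n2)ccc1[N+](=O)[O-]` and compound 3 `Nc1nc(NCCNc2ncc(-c3ncc[nH]3)c(-c3ccc(F)cc3Cl)n2)ccc1[N+](=O)[O-]`. For compound 1 this assay returned only a limit, > 0.5 h. For compound 2 this assay likewise returned only a limit, > 0.5 h. For compound 3 this assay again returned only a limit, > 0.5 h. Compound 2 thus stands at the limit of the read-out, without a number of its own. All three values shown sit at that same limit (the limit of > 0.5 h in this assay, at which 3 of the 3 values shown sit). Going by the values given here, the one single-point step among the measured compounds, a step that the two limits leave unreadable from compound 2 to compound 3, is unreadable in size, its two ends both being limits; it shows merely that an aryl exchange at this place left compound 3 at the limit as well.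

Compound 4 `Cc1cc(Cl)ccc1-c1nc(NCCNc2ccc([N+](=O)[O-])c(N)n2)ncc1-c1ncc[nH]1` has not yet been run in this assay. Compared with compound 2 the change is 4-chloro-2-methylphenyl in place of 2,4,5-trifluorophenyl on an aromatic carbon. Among the compounds with values here, no measured step gives a direction or a size for such a change, so no step beyond the scatter is expected, and the estimated step is a step that the limit leaves unreadable from compound 2 to compound 4. Compound 4 is estimated at 1.5 h, within 0.5 h to 5 h, with a fair chance that this assay again reports only a limit.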

Compound 4, half-life: > 0.5 h
Compound 4 ended at the assay's limit; the forecaster's own chance of this, stated with the estimate: 75%; the middle value lies beyond the limit too.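

The steps from compound 2 and from compound 3 to compound 4 cannot be read, with limits at both ends, and all compounds now share one limit: the limit of > 0.5 h in this assay, at which 4 of the 4 values shown sit.

The compounds shown leave open how long any of the four actually lasts in this assay, and whether these aryl exchanges alter the half-life at all.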